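Plasma Half-Life After Removing the 4-Methoxyphenyl Group

This account rests on a few compounds, and the source may have more. Where it says the series, first, only, none or still open, it means among the compounds named here.

Compound 1, `Cc1ccnc(NC(c2ccc([N+](=O)[O-])cc2)c2ccc3cccnc3c2O)c1`: 51.1 h
Compound 2, `COc1ccc(C(Nc2ccccn2)c2ccc3cccnc3c2O)cc1`: 5 h

Of the compounds shown here, two have been measured in an ADME assay on a cell-free system (plasma, Rattus norvegicus, strain Sprague-Dawley) for metabolic stability, read by LC-MS, tested at 1 uM; on this read-out higher numbers stand for a longer-lived compound and lower numbers for a shorter-lived compound. In this assay compound 1 gives 51.1 h, and in this assay compound 2 gives 5 h. Of these two numbers compound 2 stands lowest, and the gap between compound 1 and compound 2 lies beyond the usual scatter of repeated measurements of this kind.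

Compound 3, `Oc1c(CNc2ccccn2)ccc2cccnc12`, has not yet been measured. It differs from compound 2 in one place: hydrogen in place of 4-methoxyphenyl on a saturated chain carbon bound to an aromatic carbon and a nitrogen on an aromatic ring. Among the compounds with values here, no measured pair shows this same change, so its effect on the half-life is not yet known from any direct comparison. The one large gap seen so far, between compound 1 and compound 2, concerns a different change at the same place.

The step from compound 2 to compound 3 is expected to be small, perhaps a slight rise but no more than the scatter, a 1.6-fold higher number from compound 2 to compound 3 (0.20 log units; within the scatter). Compound 3 is therefore estimated at 8 h, with a range from 2 h to 30 h.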

Compound 3, half-life in the plasma assay: 12.9 h
Estimate against measurement, compound 3: 1.6-fold (0.21 log units) below; low and high end bracket the measured number.
By their numbers in the plasma assay, from the lowest: compound 2; then compound 3; then compound 1.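

Within the data shown here, this is the first direct reading of this change at this position: with hydrogen in place of 4-methoxyphenyl on the saturated chain carbon, the plasma assay shows a 2.6-fold higher number from compound 2 to compound 3 (0.41 log units; beyond the scatter), a modest step that the earlier compounds could not show. In a physicochemical assay for solubility, using the shake flask method, with a stated time of 24 h, at pH 6.8 (a lower number here means a less soluble compound, a higher number a more soluble compound), compound 2 gives 5.3 nM and compound 3 gives 111 nM. The same single change therefore moves the two read-outs by different amounts, and the larger shift is in the physicochemical assay, where losing the 4-methoxyphenyl group raises the number well beyond the scatter: the measured solubility of compound 2, 5.3 nM, and of compound 3, 111 nM, a 21-fold higher number (1.32 log units; beyond the scatter).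

Since the whole 4-methoxyphenyl group leaves in one step, these compounds cannot separate the part played by its methoxy group from that of its aromatic ring, and a plain phenyl, a methyl group or a carboxylic acid at this carbon would help to tell how each read-out follows the size and nature of the group. Compound 1 also differs from compound 2 in more than one place, so its long half-life cannot be assigned to its nitro group or to its methyl group alone.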